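The source may report more compounds than this note shows. Statements on the series, on what has been measured and on what is new or still open speak of the compounds shown alone.

Compound 1 `Cc1ccc([C@@H]2CN(C)[C@]3(C(=O)Nc4ccccc43)[C@]23Cc2ccccc2C3=O)cc1` gives 17.1% in a functional assay on the whole organism (strain Wister albino) for inhibition, with Rattus norvegicus as the target, read by paw edema, with stated times of 1 h and 4 h, at a dose of 50 mg/kg by the intraperitoneal route; on this read-out lower numbers stand for less inhibition and higher numbers for more inhibition at the one dose given (going by the name of the read-out); compound 2 `CN1C[C@@H](c2ccc(Cl)cc2)[C@@]2(Cc3ccccc3C2=O)[C@@]12C(=O)Nc1ccccc12` gives 15.6%; compound 3 `CN1C(=O)[C@@]2(c3ccccc31)N(C)C[C@@H](c1ccc(Cl)cc1)[C@@]21Cc2ccccc2C1=O` gives 8.5%. On the numbers alone compound 3 sits below the other two, but the step of a number 7.1 percentage points lower from compound 2 to compound 3 (within the scatter) and its gap to compound 1 both fall within the scatter, so the three are not separated. Compound 4 `COc1ccc([C@@H]2CN(C)[C@]3(C(=O)N(C)c4ccccc43)[C@]23Cc2ccccc2C3=O)cc1` differs from compound 3 by methoxy in place of chloro on an aromatic carbon. Within the data shown here, the one measured step on the same aromatic carbon is a number 1.5 percentage points lower from compound 1 to compound 2 (within the scatter), a swap of one small group for another that stayed within the scatter; nothing measured covers methoxy there. No step beyond the scatter is therefore expected in this assay, and the change expected is a number 1.5 percentage points higher from compound 3 to compound 4 (within the scatter). Compound 4 is estimated at 10%, within 2% to 20%.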

Compound 4, a percentage reported as inhibition, in the whole organism at one dose (the size of the read-out at that dose, not a potency): 3.8%
Beside the measured number, compound 4's estimate is 6.2 percentage points above it; the range from low to high includes it.
By their numbers in this assay, from the lowest: compounds 4, 3, 2 and 1 (each within the scatter of the next, the first and the last beyond it).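

In this assay, the change to 4-methoxyphenyl from 4-chlorophenyl gives a number 4.7 percentage points lower from compound 3 to compound 4 (within the scatter), so a group with a hydrogen-bond acceptor on this aromatic carbon still produces no step beyond the scatter. Together with a number 1.5 percentage points lower from compound 1 to compound 2 (within the scatter), this makes two swaps at this position that remain within the scatter, though in series differing at the amide nitrogen. The compounds shown leave open whether an amine or a carboxylic acid on this aromatic carbon would give a step beyond the scatter. No measured evidence bears on this result.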